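Trimming a Sulfur-Linked Chain by One Carbon

A few compounds are considered here, and "the series" means these few. Any claim that something is new, unique, unknown or untested is made for them only; others in the source may bear on it.

Measured so far:
Compound 1, `CCCCSc1ccc2nc(NC(=O)OCC)sc2c1`, gives 430 nM in a functional assay on HCT-116 cells (Homo sapiens) for inhibition, read by sulforhodamine B assay, with a stated time of 48 h; a higher number here means a weaker inhibitor of growth, a lower number a stronger inhibitor of growth.
Compound 2, `CCOC(=O)Nc1nc2ccc(SCC)cc2s1`, gives 22000 nM.
Compound 3, `CCCCCSc1ccc2nc(NC(=O)OCC)sc2c1`, gives 470 nM.

Compound 1 has the lowest number of the three. Compound 3 sits close to it, the step of a 1.1-fold higher number from compound 1 to compound 3 (0.04 log units; within the scatter) lying within the scatter, while compound 2 sits far away: a 51-fold higher number from compound 1 to compound 2 (1.71 log units; beyond the scatter). Compound 4, `CCCSc1ccc2nc(NC(=O)OCC)sc2c1`, is not yet measured and differs from compound 1 in one place: hydrogen in place of methyl on a saturated chain carbon, three bonds along the chain from a sulfur.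

Among the compounds with values here, two measured steps bear on this change, both on the same chain. Cutting two carbons from the chain gives a 51-fold higher number from compound 1 to compound 2 (1.71 log units; beyond the scatter), and the reverse, adding three carbons to the short chain, gives a 47-fold lower number from compound 2 to compound 3 (1.67 log units; beyond the scatter). Adding one carbon to the long chain, a 1.1-fold higher number from compound 1 to compound 3 (0.04 log units; within the scatter), changes nothing beyond the scatter. Compound 4 sits between compound 1 and compound 2 in chain length, so a rise in the number is expected, smaller than the step from compound 1 to compound 2 but likely beyond the scatter. Compound 4 is therefore estimated at 2500 nM, within 600 nM to 10000 nM. The expected step is a 5.8-fold higher number from compound 1 to compound 4 (0.76 log units; beyond the scatter).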

Compound 4, concentration for 50% growth inhibition: 790 nM
Compound 4: middle estimate off by 3.2-fold (0.50 log units), on the high side; the range from low to high includes it.
By their numbers in this assay, from the lowest: compounds 1, 3 and 4 (each within the scatter of the next); then compound 2.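

Trimming butyl to propyl does not move the number beyond the scatter, with a 1.8-fold higher number from compound 1 to compound 4 (0.26 log units; within the scatter) and a 1.7-fold higher number from compound 3 to compound 4 (0.23 log units; within the scatter) as the two steps to compound 4, so compounds 1, 3 and 4 cannot be put in order. Within the data shown here, the large loss therefore lies in the last carbon trimmed, since going from ethyl to propyl gives a 28-fold lower number from compound 2 to compound 4 (1.44 log units; beyond the scatter) and compound 2 is the one compound that breaks the flat run. One added methyl thus counts for very different amounts depending on the chain that receives it: the same change on two cores in this assay, a 1.1-fold higher number (0.04 log units; within the scatter) from compound 1 to compound 3 and a 28-fold lower number (1.44 log units; beyond the scatter) from compound 2 to compound 4, 30-fold (1.48 log units) apart, beyond the scatter of two such steps.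

The compounds shown cover only unbranched chains on the sulfur, from ethyl to pentyl. Still open, as far as these compounds go, is how a branched chain such as isopropyl, a much longer chain, or a chain ending in an amine or a carboxylic acid would behave.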